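The compounds below may be only part of what the source reports. "The series", "measured", "known", "first", "only" and "open" are said of these compounds alone.

Working notes on the series, read out in a functional assay on HepG2 cells (Homo sapiens) for inhibition, read by MTT assay, with a stated time of 72 h; on this read-out lower numbers stand for stronger inhibition and higher numbers for weaker inhibition. Of the compounds shown here, two have numbers so far. Compound 1 `COc1cc(O)cc(O)c1C(=O)/C=C/c1ccc(C(F)(F)F)cc1` gives 14100 nM and compound 2 `COc1cc(OC)c(C(=O)/C=C/c2ccc(O)cc2)c(OC)c1` gives 37000 nM. Compound 2 therefore holds the higher of the two numbers, and its gap to compound 1 lies beyond the usual scatter. Among the measured compounds shown here, these two compounds differ in more than one place, so no measured pair isolates a single change.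

Compound 3 `COc1cc(OC)c(C(=O)/C=C/c2ccc(O)c(O)c2)c(OC)c1` is still unmeasured. Its difference from compound 2 is hydroxy in place of hydrogen on an aromatic carbon, ortho to a hydroxy group and meta to a large group. The same change reads as 4-hydroxyphenyl to 3,4-dihydroxyphenyl.

For the measured compounds named here, with no direct precedent for this step, the expectation rests on the narrow span of the data, with compound 2 at 37000 nM and compound 1 at 14100 nM. A modest move toward stronger inhibition is expected, of a size near the scatter, and the estimated change is a 1.7-fold lower number from compound 2 to compound 3 (0.23 log units; within the scatter). In this assay the estimate for compound 3 is 22000 nM, with an expected range of 8000 nM to 55000 nM.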

Compound 3, half-maximal inhibitory concentration: 27500 nM
For compound 3 the middle estimate is 1.3-fold (0.10 log units) below the measured one; the range from low to high includes it.
By their numbers in this assay, from the lowest: compounds 1, 3 and 2 (each within the scatter of the next, the first and the last beyond it).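

In this assay, among the compounds shown here, the change from 4-hydroxyphenyl to 3,4-dihydroxyphenyl gives a 1.3-fold lower number from compound 2 to compound 3 (0.13 log units; within the scatter), the only step so far that isolates a single change. At this aromatic carbon, ortho to a hydroxy group and meta to a large group, hydroxy in place of hydrogen therefore leaves the two compounds indistinguishable in this read-out, with neither a gain nor a loss beyond the scatter, so the position accepts this added group without a resolved shift in either direction. No independent measurement is available to account for the size of this step.

The compounds shown leave open whether a different group on this same aromatic carbon, such as an amine or a carboxylic acid, would move the number beyond the scatter, since hydroxy is the only replacement for hydrogen that can be read here. For the compounds shown here, also open is whether the same hydroxy change would read alike on the core of compound 1, where no matching pair is available to test it.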